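Swapping a Benzyl Substituent in a Sulfonamide Series

The source may hold more compounds than are shown below. What is called first, only, known or untested is meant among the compounds shown, and "the series" means these compounds.

Compound 1 `CC(C)(C)c1ccc(CNCCNS(=O)(=O)c2cc(C(F)(F)F)cc(C(F)(F)F)c2)cc1` gives 14000 nM.
Compound 2 `O=S(=O)(NCCNCc1ccc(-c2ccccc2)cc1)c1cc(C(F)(F)F)cc(C(F)(F)F)c1` gives 2700 nM.
Compound 3 `O=S(=O)(NCCCNCc1ccc(C(F)(F)F)cc1)c1cc(C(F)(F)F)cc(C(F)(F)F)c1` gives 2900 nM.

All three were measured in a functional assay on HT-29 cells (Homo sapiens) for inhibition, read by MTT assay, with a stated time of 72 h; a higher number here means a weaker inhibitor of growth, a lower number a stronger inhibitor of growth. Among these three numbers compound 3 stands second highest. Its nearest neighbour is compound 2, whose number lies within the usual scatter of that of compound 3, so the two cannot be told apart. Compound 1 lies furthest away, with a higher number that is beyond the scatter.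

Within the data shown here, only one measured step joins two compounds that differ in a single place: a 5.2-fold lower number from compound 1 to compound 2 (0.71 log units; beyond the scatter), with phenyl in place of tert-butyl on an aromatic carbon.

Compound 4 `COc1ccc(CNCCCNS(=O)(=O)c2cc(C(F)(F)F)cc(C(F)(F)F)c2)cc1` is the next compound. Compared with compound 3, the change is methoxy in place of trifluoromethyl on an aromatic carbon. No measured step covers this exchange: the one step shown, from tert-butyl to phenyl, concerns different groups on a different benzyl ring, and it was only modest in size. There is therefore no direct guide, and the expectation is for no step beyond the scatter in this assay.

Compound 4 is thus estimated at 3000 nM, in a range from 1200 nM to 8000 nM, which means an expected step of a 1.0-fold higher number from compound 3 to compound 4 (0.01 log units; within the scatter).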

Compound 4, concentration for 50% growth inhibition: 2900 nM
Estimate against measurement, compound 4: 1.0-fold (0.01 log units) above; the range from low to high includes it.
By their numbers in this assay, from the lowest: compounds 2, 3 and 4 (each within the scatter of the next); then compound 1.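

Exchanging 4-(trifluoromethyl)benzyl for 4-methoxybenzyl gives no change at the digits printed from compound 3 to compound 4 (within the scatter) in this assay. A group of 4 heavy atoms with 0 hydrogen-bond acceptors leaves and a group of 2 heavy atoms with 1 hydrogen-bond acceptor enters, yet this position, para to a large group, tolerates the swap with no readable shift, whereas the earlier exchange of tert-butyl for phenyl gave a 5.2-fold lower number from compound 1 to compound 2 (0.71 log units; beyond the scatter), so not every exchange of a group on a benzyl ring in this series moves the number. Nothing measured here offers an explanation for why these two groups read alike.

Going by these compounds, whether a carboxylic acid, an amine or a plain hydrogen on this same aromatic carbon would also leave the number in place remains open, since two groups alone cannot show how much freedom the position allows. On these data alone, it is also open whether trifluoromethyl and methoxy would still read alike on a longer chain or in a core carrying another sulfonyl-bound ring.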